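This account rests on a few compounds, and the source may have more. Where it says the series, first, only, none or still open, it means among the compounds named here.

Values in a functional assay on SK-OV-3 cells (Homo sapiens) for antiproliferative activity, read by MTT assay, with a stated time of 72 h; a higher number here means a weaker inhibitor, a lower number a stronger inhibitor:
- compound 1 `O=C(CCc1cccc2c1B(O)OC2)Nc1ccccc1`: 200 nM
- compound 2 `C#Cc1cccc(NC(=O)CCc2cccc3c2B(O)OC3)c1`: 980 nM
- compound 3 `COc1cc(OC)cc(-c2cccc(NC(=O)CCc3cccc4c3B(O)OC4)c2)c1`: 44 nM

Compound 3 has the lowest number of the three, shown by a 4.5-fold lower number from compound 1 to compound 3 (0.66 log units; beyond the scatter) and a 22-fold lower number from compound 2 to compound 3 (1.35 log units; beyond the scatter). Compound 4 `O=C(CCc1cccc2c1B(O)OC2)Nc1cccc(-c2cccc(C(F)(F)F)c2)c1` carries 3-(trifluoromethyl)phenyl in place of 3,5-dimethoxyphenyl on an aromatic carbon. Within the data shown here, no measured step exchanges one such ring for another. The modest 4.5-fold lower number from compound 1 to compound 3 (0.66 log units; beyond the scatter) and the large 22-fold lower number from compound 2 to compound 3 (1.35 log units; beyond the scatter) bear on it only indirectly, as compound 4 keeps a ring there. In this assay, a small step towards a higher number is expected, possibly within the scatter: the estimate is a 1.8-fold higher number from compound 3 to compound 4 (0.26 log units; within the scatter). For compound 4 the estimated value is 80 nM, with an expected range from 30 nM to 220 nM.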

Compound 4, half-maximal inhibitory concentration: 390 nM
Estimate against measurement, compound 4: 4.9-fold (0.69 log units) below, and the stated range ends below it.
By their numbers in this assay, from the lowest: compound 3; then compounds 1 and 4 (each within the scatter of the next); then compound 2.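

In this assay, a substituted phenyl ring at this place does not by itself bring the lower number seen for compound 3, since exchanging 3,5-dimethoxyphenyl for 3-(trifluoromethyl)phenyl gives a clear loss (an 8.9-fold higher number from compound 3 to compound 4 (0.95 log units; beyond the scatter)). The 3-(trifluoromethyl)phenyl ring does not separate from hydrogen (a 2.0-fold higher number from compound 1 to compound 4 (0.29 log units; within the scatter)) but still improves on ethynyl (a 2.5-fold lower number from compound 2 to compound 4 (0.40 log units; beyond the scatter)). No measurement on these compounds accounts for the gap between the two rings. Still open, going by these compounds, is whether the methoxy groups or their placement on the ring drive the lower number of compound 3, and how an amine or a carboxylic acid on that ring would read.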